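The source may hold more compounds than are shown below. What is called first, only, known or untested is meant among the compounds shown, and "the series" means these compounds.

Working notes on the series. Among the compounds with values here, in a functional assay on BT-549 cells (Homo sapiens) for cytotoxicity, read by sulforhodamine B assay, with a stated time of 48 h (a higher number here means that more compound is tolerated, a lower number that less compound is tolerated), compound 1 `ClCc1cccc(Cn2cnc3nc(Cl)nc(Cl)c32)c1` gives 4160 nM, the lowest of the two numbers measured so far. Compound 2 `ClCc1ccc(Cn2cnc3c(Cl)nc(Cl)nc32)cc1` gives 56200 nM in this assay, a higher number that lies beyond the usual scatter. Compound 3 `ClCc1cccc(Cn2cnc3ncnc(Cl)c32)c1` differs from compound 1 by hydrogen in place of chloro on an aromatic carbon. Within the data shown here, no measured pair isolates this change, so its direction is open; a modest rise in the number, near the edge of the scatter, is expected rather than a large one. Compound 3 is estimated at 8000 nM in this assay, within 2500 nM to 30000 nM, which means an expected step of a 1.9-fold higher number from compound 1 to compound 3 (0.28 log units; within the scatter).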

Compound 3, concentration lethal to 50% of the cells: 63100 nM
For compound 3 the middle estimate is 7.9-fold (0.90 log units) below the measured one; the measured number lies above the stated range.
By their numbers in this assay, from the lowest: compound 1; then compounds 2 and 3 (each within the scatter of the next).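

Hydrogen in place of chloro on an aromatic carbon, between two ring nitrogen atoms, gives the first one-place step of the series: in this assay it is a 15-fold higher number from compound 1 to compound 3 (1.18 log units; beyond the scatter). This chloro group therefore matters greatly at this position, and its loss leaves much more compound tolerated. Nothing measured here accounts for the size of this step. From the compounds shown here alone, whether an amine, a methoxy group or fluoro at this position would keep the lower number stays open, as does whether the same change would give a similar step on the core of compound 2.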